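The source may hold more compounds than are shown below. What is called first, only, known or untested is meant among the compounds shown, and "the series" means these compounds.

Measured so far:
- compound 2 `O=C1C2CCCCN2C(=O)N1CCCCN1CCN(c2ccccc2)CC1`: 18.6 nM in an assay on isolated protein for binding affinity to Adrenergic receptor alpha-1 (Rattus norvegicus), read by radioligand binding; a lower number here means a stronger inhibitor, a higher number a weaker inhibitor
- compound 1 `O=C1C2CCCCN2C(=O)N1CCCN1CCN(c2cccc(C(F)(F)F)c2)CC1`: 90.4 nM in this assay

Of these two numbers, compound 2 has the lower one; compound 1 stands higher, and that gap is beyond the usual scatter of this kind of measurement. Compound 1 and compound 2 differ in two places at once, in the length of the chain and in the group on the aromatic ring, so their two values alone cannot be split into a share for each change.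

Compound 3 `O=C1C2CCCCN2C(=O)N1CCCCN1CCN(c2cccc(C(F)(F)F)c2)CC1` keeps the chain of compound 2 and differs from it in one place: trifluoromethyl in place of hydrogen on an aromatic carbon. Among the compounds with values here, with no single-change step measured here, the expectation rests on the two values above and on the nature of the change. The two structures that carry the trifluoromethyl group, compound 1 and compound 3, sit close in that respect, and compound 1 shows the higher number of the two measured. A modest rise in the number, at most somewhat beyond the scatter, is therefore expected for compound 3, as the step of a 2.4-fold higher number from compound 2 to compound 3 (0.38 log units; beyond the scatter) expresses. Compound 3 is estimated at 45 nM, in a range from 15 nM to 150 nM.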

Compound 3, inhibition constant: 72.4 nM
For compound 3 the middle estimate is 1.6-fold (0.21 log units) below the measured one, and the stated range covers the measured number.
By their numbers in this assay, from the lowest: compound 2; then compounds 3 and 1 (each within the scatter of the next).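

With the chain held fixed, the effect of this one change can now be read on its own: in this assay, trifluoromethyl in place of hydrogen on the aromatic ring gives a 3.9-fold higher number from compound 2 to compound 3 (0.59 log units; beyond the scatter), so on this chain the substituted ring binds less tightly than plain phenyl. Within the data shown here, the compounds also offer a first look at chain length with the 3-(trifluoromethyl)phenyl group in place: compound 3 gives 72.4 nM and compound 1, with the shorter chain, gives 90.4 nM, and these two values lie within the scatter of each other, so on this ring the difference in chain length shows no measurable effect. Nothing available here explains why the trifluoromethyl group raises the number.

As far as these compounds go, what a plain phenyl group would give on the shorter chain stays open, and with it whether the trifluoromethyl step has the same size on both chains. Also open, from the compounds shown here alone, is whether a chlorine atom or a methoxy group at the same place on the ring, or a longer chain, would give a number closer to that of compound 2.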